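Fluoro to methyl on the phenoxy ring: cytotoxicity notes

The source may report more compounds than this note shows. Statements on the series, on what has been measured and on what is new or still open speak of the compounds shown alone.

Measured so far:
compound 2 `O=C1N(CCCCCCOc2ccc(F)cc2)CCN1c1cccnc1`: > 25000 nM
compound 1 `Cc1ccc(OCCCCCCN2CCN(c3ccncc3)C2=O)cc1`: > 25000 nM

In a functional assay on cells (Homo sapiens) for cytotoxicity (on this read-out lower numbers stand for higher toxicity in this test and higher numbers for lower toxicity in this test), compound 2 gives > 25000 nM, which is a limit of the assay and not a number. Compound 1 gives > 25000 nM, likewise a limit. Among the compounds with values here, both readings therefore sit on (the limit of > 25000 nM in this assay, at which 2 of the 2 values shown sit), so compound 2 stands exactly where the only other measured compound stands, and neither shows measurable toxicity in this assay. Compound 1 and compound 2 differ in more than one place, so their pair shows only that both are limits.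

Compound 3 `Cc1ccc(OCCCCCCN2CCN(c3cccnc3)C2=O)cc1` differs from compound 2 by methyl in place of fluoro on an aromatic carbon. Within the data shown here, no measured step of this kind exists, so the size of the step in this assay can only be expected, not read off. The expectation is for no step beyond the scatter: the step from compound 2 to compound 3 is expected to be a step that the limit leaves unreadable from compound 2 to compound 3. For compound 3 the estimated value in this assay is 40000 nM, with a range from 20000 nM to 100000 nM, most likely reported again only as a limit.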

Compound 3, half-maximal cytotoxic concentration: > 25000 nM
Compound 3 ended at the assay's limit; the forecaster's own chance of this, stated with the estimate: 85%; the middle value does not contradict the limit.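

Neither the step from compound 2 to compound 3 nor the step from compound 1 to compound 3 can be read, and all three compounds stand at one value: the limit of > 25000 nM in this assay, at which 3 of the 3 values shown sit.

The compounds shown leave open whether methyl in place of fluoro, or pyridin-3-yl in place of pyridin-4-yl, alters toxicity in this assay at all.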